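The compounds below may be only part of what the source reports. "The series", "measured", "known", "first", "only" and "open" are said of these compounds alone.

Compound 1 `COc1cncc(N2CCCNCCC2)c1`: 1 nM
Compound 2 `c1cncc(N2CCCNCCC2)c1`: 0.9 nM
Compound 3 `Brc1ccc(N2CCCNCCC2)cn1`: 0.45 nM

All three share one core and were tested in an assay (strain Wistar) for binding affinity to Neuronal acetylcholine receptor; alpha4/beta2 (Rattus norvegicus); a lower number here means a stronger inhibitor, a higher number a weaker inhibitor. Compound 2 holds the second highest of the three numbers; its nearest neighbour is reached by a 1.1-fold lower number from compound 1 to compound 2 (0.05 log units; within the scatter), its furthest by a 2.0-fold lower number from compound 2 to compound 3 (0.30 log units; within the scatter), and both of these steps lie within the scatter. Compound 4 `Brc1cncc(N2CCCNCCC2)c1` has not been measured yet. It differs from compound 2 in one place: bromo in place of hydrogen on an aromatic carbon. Within the data shown here, the only measured step of the same kind, a bromo entering for a hydrogen, is the one from compound 2 to compound 3, and it stayed within the scatter. The step to compound 4 is therefore expected to be small, a 1.5-fold lower number from compound 2 to compound 4 (0.18 log units; within the scatter), if anything toward a lower number. Compound 4 is estimated at 0.6 nM, in a range from 0.25 nM to 1.5 nM.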

Compound 4, half-maximal inhibitory concentration: 2.8 nM
For compound 4 the middle estimate is 4.7-fold (0.67 log units) below the measured one; the whole stated range lies below it.
By their numbers in this assay, from the lowest: compounds 3, 2 and 1 (each within the scatter of the next, the first and the last beyond it); then compound 4.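

In this assay, among these compounds, bromo on this carbon, two atoms from the ring nitrogen, gives the first step beyond the scatter, a 3.1-fold higher number from compound 2 to compound 4 (0.49 log units; beyond the scatter). Replacing methoxy with bromo on the same carbon points the same way, a 2.8-fold higher number from compound 1 to compound 4 (0.45 log units; beyond the scatter), although methoxy and hydrogen there lie within the scatter of each other. Bromo's effect therefore depends on its ring position, as the bromo on another carbon gave only a 2.0-fold lower number from compound 2 to compound 3 (0.30 log units; within the scatter) and stayed within the scatter.

Nothing measured here explains this shift. From the compounds shown here alone, whether a chloro, an amine or a longer chain on this carbon would follow bromo or stay with hydrogen and methoxy remains open.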